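Pentafluoroethyl on the Triazole: Expected Effect on Clearance

The source may hold more compounds than are shown below. What is called first, only, known or untested is meant among the compounds shown, and "the series" means these compounds.

Measured compounds:
compound 1, `Cc1ncc(Cc2nc(-c3nc(C(F)(F)F)n[nH]3)n3ccccc23)cn1`, < 8 mL.min-1.g-1
compound 2, `Fc1ccccc1Cc1nc(-c2ncn[nH]2)n2ccccc12`, 175 mL.min-1.g-1

Among the compounds with values here, in an in vitro ADME assay on microsomes from liver (Homo sapiens) for metabolic stability (a higher number here means faster removal of the compound, a lower number slower removal), compound 2 gives 175 mL.min-1.g-1, the only plain number among the results. Compound 1 carries a trifluoromethyl on its five-membered ring, and in this assay compound 1 gives < 8 mL.min-1.g-1, which is a limit of the assay rather than a number; it sits at the limit of < 8 mL.min-1.g-1 in this assay, at which 1 of the 2 values shown sits. Within the data shown here, no step between two measured compounds is available, so the two results can only be set side by side.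

Compound 3 is `Fc1ccccc1Cc1nc(-c2nc(C(F)(F)C(F)(F)F)n[nH]2)n2ccccc12`, not yet measured in this assay. It differs from compound 2 by 1,1,2,2,2-pentafluoroethyl in place of hydrogen on an aromatic carbon, on the same five-membered ring that carries the trifluoromethyl in compound 1.

The step from compound 2 to compound 3 is expected to be large and downward, well beyond the scatter: an 8.8-fold lower number from compound 2 to compound 3 (0.94 log units; beyond the scatter). Compound 3 is expected to give about 20 mL.min-1.g-1 in this assay, in a range from 5 mL.min-1.g-1 to 70 mL.min-1.g-1, with a fair chance that only a limit is reported.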

Compound 3, intrinsic clearance in microsomes: 92 mL.min-1.g-1
The estimate for compound 3 lay 4.6-fold (0.66 log units) below the measured number; measured number outside the range, above it.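

The new step is a 1.9-fold lower number from compound 2 to compound 3 (0.28 log units; within the scatter) in this assay, so this measurement does not separate the two compounds. The earlier compounds shown here offered no direct reading at this position, the aromatic carbon between two ring nitrogen atoms of the five-membered ring. Here, 1,1,2,2,2-pentafluoroethyl, with its 7 heavy atoms, takes the place of hydrogen without a change that can be told apart from the usual variation between repeated measurements, and nothing shown gives a cause for this result.

Compound 1 gives < 8 mL.min-1.g-1, which is a limit of the assay. Compound 1 differs from compound 3 in more than one place, and the compounds shown cannot connect that limit to any single one of its groups. As far as these compounds go, it remains open how compound 2 would compare with a version carrying trifluoromethyl alone, an amine or a carboxylic acid on this same carbon, and whether 1,1,2,2,2-pentafluoroethyl would behave the same way if the rest of the molecule matched compound 1.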